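Methyl in place of dimethylamino: expecting a number again

This account rests on a few compounds, and the source may have more. Where it says the series, first, only, none or still open, it means among the compounds named here.

Three compounds have been measured:
Compound 1, `O=S(=O)(Nc1cccc(CO)c1)c1ccc(-c2ccccc2)cc1`, gives 2200 nM in a functional assay on J774 cells (Mus musculus) for cytotoxicity, read by resazurin assay, with a stated time of 72 h; on this read-out lower numbers stand for stronger inhibition and higher numbers for weaker inhibition.
Compound 2, `O=S(=O)(Nc1cccc(CO)c1)c1ccc(-c2ccc(F)cc2)cc1`, gives 3500 nM in this assay.
Compound 3, `CN(C)c1ccc(-c2ccc(S(=O)(=O)Nc3cccc(CO)c3)cc2)cc1`, gives > 5000 nM in this assay, which is a limit of the assay and not a number.

Compound 3 therefore sits at the weak end of what has been seen, at the limit of > 5000 nM in this assay, at which 1 of the 3 values shown sits. The step of an at least 2.2-fold higher number from compound 1 to compound 3 (0.35 log units; beyond the scatter) is beyond the scatter, whereas a 1.6-fold higher number from compound 1 to compound 2 (0.20 log units; within the scatter) and an at least 1.4-fold higher number from compound 2 to compound 3 (0.15 log units; that floor lies within the scatter) are not.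

Compound 4, `Cc1ccc(-c2ccc(S(=O)(=O)Nc3cccc(CO)c3)cc2)cc1`, differs from compound 3 by methyl in place of dimethylamino on an aromatic carbon. The measured steps that bear on this change are those that vary the same position: a 1.6-fold higher number from compound 1 to compound 2 (0.20 log units; within the scatter) and an at least 2.2-fold higher number from compound 1 to compound 3 (0.35 log units; beyond the scatter). A small group there, hydrogen or fluoro, went with a number; the larger dimethylamino went with a limit. Methyl is small like fluoro, so in this assay compound 4 is expected to return to a measurable number, and the step of an at least 1.7-fold lower number from compound 3 to compound 4 (0.25 log units; that floor lies within the scatter) is expected to run toward a lower number.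

Compound 4 is estimated at 2800 nM, within a range from 1300 nM to 6000 nM.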

Compound 4, half-maximal inhibitory concentration: 1200 nM
Estimate against measurement, compound 4: 2.3-fold (0.37 log units) above; measured number outside the range, below it.
By their numbers in this assay, from the lowest: compounds 4, 1 and 2 (each within the scatter of the next, the first and the last beyond it). At a limit, above all of these: compound 3.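

Compound 3 stands at a limit of the assay and not at a number, so in this assay the step of an at least 4.1-fold lower number from compound 3 to compound 4 (0.61 log units; beyond the scatter) is only a floor: the limit of > 5000 nM in this assay, at which 1 of the 4 values shown sits.

For the compounds shown here, what is new is that the groups giving a number at this aromatic carbon can now be told apart: methyl in place of fluoro gives a 2.9-fold lower number from compound 2 to compound 4 (0.46 log units; beyond the scatter), whereas hydrogen and fluoro, the only such pair before, lay within the scatter of each other. Methyl and hydrogen, however, cannot be separated in this assay, since the comparison gives a 1.8-fold lower number from compound 1 to compound 4 (0.26 log units; within the scatter), so the change that stands out is the one from fluoro and not any gain over the plain hydrogen.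

From the compounds shown here alone, whether a methoxy group, a longer chain such as propyl, or a primary amine at the same aromatic carbon would behave like methyl or like dimethylamino remains open. The values also give no reason why methyl and fluoro differ, and they say nothing about changes elsewhere on the shared core.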